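The source may hold more compounds than are shown below. What is called first, only, known or untested is meant among the compounds shown, and "the series" means these compounds.

In an assay on isolated protein for inhibition of Rho-associated protein kinase 2 (Homo sapiens), read by scintillation counting, radiometric assay and 33P incorporation, with a stated time of 40 min, in the presence of a further agent that is not named here (on this read-out lower numbers stand for stronger inhibition and higher numbers for weaker inhibition), compound 2 `Cc1cc(C(=O)Nc2cccc(NC(=O)COc3ccc4c(=O)ccoc4c3)c2)ccc1C(F)(F)F` gives 43 nM. Its only measured companion, compound 1 `O=C(COc1ccc2c(=O)ccoc2c1)Nc1cccc(NC(=O)c2ccc(Br)cc2)c1`, gives 49 nM in this assay, and the two numbers lie within the scatter of each other. Among the measured compounds shown here, the single measured step, a 1.1-fold lower number from compound 1 to compound 2 (0.06 log units; within the scatter), exchanged one six-membered aromatic ring of carbon only for another on the carbonyl carbon and left the read-out essentially unchanged. Compound 3 `Nc1ccc(C(=O)Nc2cccc(NC(=O)COc3ccc4c(=O)ccoc4c3)c2)cc1` is not yet measured. It differs from compound 2 in this way: a group of 7 heavy atoms (6 carbon, 1 nitrogen; one six-membered aromatic ring of carbon only) in place of a group of 11 heavy atoms (8 carbon, 3 fluorine; one six-membered aromatic ring of carbon only), on a carbonyl carbon; the 4-aminophenyl group brings one hydrogen-bond donor and one hydrogen-bond acceptor, where the group that leaves has none. For the measured compounds named here, only that one step bears on this change, and it was within the scatter, so no step beyond the scatter is expected for compound 3, estimated as a 1.4-fold higher number from compound 2 to compound 3 (0.14 log units; within the scatter). Compound 3 is therefore expected at 60 nM, with a range from 20 nM to 180 nM.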

Compound 3, half-maximal inhibitory concentration: 83 nM
Compound 3: the middle estimate sits 1.4-fold (0.14 log units) below what was measured; the measured number falls inside the stated range.
By their numbers in this assay, from the lowest: compounds 2, 1 and 3 (each within the scatter of the next).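

In this assay, putting 4-aminophenyl on the carbonyl carbon, a group that brings a hydrogen-bond donor and acceptor, gives a 1.9-fold higher number from compound 2 to compound 3 (0.29 log units; within the scatter), and amino in place of bromo on an aromatic carbon gives a 1.7-fold higher number from compound 1 to compound 3 (0.23 log units; within the scatter). Both steps lie within the scatter, so this position now holds three different groups, one of them carrying an amino group, with no difference that can be told from ordinary measurement noise. Nothing measured here explains why these groups read alike.

Still open, going by these compounds, is whether any group at this position would move the number beyond the scatter, for instance a carboxylic acid or a piperidine ring on the aromatic ring. The compounds also leave open how a change elsewhere in the shared core, such as a longer chain, would read.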